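The compounds below may be only part of what the source reports. "The series", "measured", "known", "first", "only" and "open" are said of these compounds alone.

Three compounds have been measured in an assay for inhibition of methylcytosine dioxygenase TET2 (Homo sapiens), read by mass spectrometry, with stated times of 30 min and 1 h; a higher number here means a weaker inhibitor, a lower number a stronger inhibitor:

compound 1 `Cc1oncc1NS(=O)(=O)c1ccc(F)c2ncc(I)cc12` gives 2100 nM;
compound 2 `CC(C)OS(=O)(=O)c1ccc(F)c2ncc(I)cc12` gives > 200000 nM;
compound 3 `Nc1cccc(OS(=O)(=O)c2ccc(F)c3ncc(I)cc23)c1` gives > 200000 nM.

The value of compound 2 is a limit of the assay and not a number. The same holds for compound 3. Compound 2 thus stands at the weak end of what is shown, and the limit of > 200000 nM in this assay, at which 2 of the 3 values shown sit, marks where it sits. The unmeasured compound 4 `O=S(=O)(c1ccc(F)c2ncc(I)cc12)N1CCCC1` differs from compound 2 by pyrrolidin-1-yl in place of isopropoxy on a sulfonyl sulfur. Among the compounds with values here, one measured step bears on this position: an at least 95-fold higher number from compound 1 to compound 2 (1.97 log units; beyond the scatter), a move from a sulfonamide carrying a methyl-isoxazolyl group to a sulfonate ester, which cost a large amount of inhibition. A second step, a step that the two limits leave unreadable from compound 2 to compound 3, leaves no readable size, as both of its values are limits. Compound 4 reverses the ester back to a sulfonamide, though one whose nitrogen carries no hydrogen. One therefore expects a gain in this assay from compound 2 to compound 4, likely smaller than the loss seen going to the ester, estimated as an at least 5.0-fold lower number from compound 2 to compound 4 (0.69 log units; beyond the scatter). For compound 4 the estimate is 40000 nM, expected to lie within 4000 nM to 200000 nM.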

Compound 4, half-maximal inhibitory concentration: > 200000 nM
Compound 4: only a limit was reported; the forecaster's own chance of this, stated with the estimate: 35%; middle value at least 5.0-fold (0.69 log units) from the limit.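

In this assay compound 4 gives > 200000 nM, which is a limit of the assay and not a number. A sulfonamide link on the sulfonyl sulfur is therefore not enough on its own to keep measurable inhibition, since pyrrolidin-1-yl, whose nitrogen carries no hydrogen, in place of the group of compound 1 gives an at least 95-fold higher number from compound 1 to compound 4 (1.97 log units; beyond the scatter), a large step beyond the scatter, whereas the earlier compounds had shown such a loss only for sulfonate esters. The steps from compound 2 to compound 3 and to compound 4 cannot be read, as both ends of each are limits, so the three groups cannot be ranked against one another, and only compound 1 stands clear of the limit of this series: the limit of > 200000 nM in this assay, at which 3 of the 4 values shown sit.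

The compounds shown leave open whether the inhibition of compound 1 goes with the hydrogen on its sulfonamide nitrogen or with its methyl-isoxazolyl ring. A simple secondary amine on the sulfonyl sulfur, such as methylamino or anilino, would bear on that question, as would a phenyl ring in place of the methyl-isoxazolyl group.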